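Lengthening the nitrogen chain on a trimethoxybenzoyl compound

A few compounds are considered here, and "the series" means these few. Any claim that something is new, unique, unknown or untested is made for them only; others in the source may bear on it.

Compound 1 `COc1cc(C(=O)c2cccc3c2ccn3C)cc(OC)c1OC` gives 22.1 nM
Compound 2 `COc1cc(C(=O)c2ccc3c(ccn3C)c2)cc(OC)c1OC` gives 13.6 nM

In a functional assay on KB cells (Homo sapiens) for inhibition, with a stated time of 72 h (on this read-out higher numbers stand for weaker inhibition and lower numbers for stronger inhibition), compound 2 stands at 13.6 nM and compound 1 at 22.1 nM and these two numbers lie within the scatter of each other. The next compound to be tested is compound 3 `CCCn1ccc2cc(C(=O)c3cc(OC)c(OC)c(OC)c3)ccc21` which differs from compound 2 in one place. The difference is ethyl in place of hydrogen on a saturated chain carbon bound to an aromatic nitrogen and it puts ethyl in place of hydrogen on a saturated chain carbon bound to an aromatic nitrogen, so that methyl becomes propyl. Going by the values given here, no measured pair here shows what such a change does, so the expectation rests on the structural change alone. Weaker inhibition is expected, with an estimated 4.4-fold higher number from compound 2 to compound 3 (0.64 log units; beyond the scatter) in this assay that clearly exceeds the scatter. For compound 3 the expected value is 60 nM with a likely range from 15 nM to 300 nM in this estimate.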

Compound 3, half-maximal inhibitory concentration: 1900 nM
Estimate against measurement, compound 3: 32-fold (1.50 log units) below; the measured number lies above the stated range.
By their numbers in this assay, from the lowest: compounds 2 and 1 (each within the scatter of the next); then compound 3.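

In this assay, replacing methyl with propyl on this saturated chain carbon bound to an aromatic nitrogen gives a 140-fold higher number from compound 2 to compound 3 (2.15 log units; beyond the scatter), a large step for the addition of only an ethyl group with 2 heavy atoms. Going by these compounds alone, compound 1 and compound 2 both carry methyl at this place, so only this step reveals that the read-out is highly sensitive to the chain on the nitrogen. Nothing available here accounts for the size of this loss.

The compounds shown leave open whether a shorter ethyl chain would already bring much of the loss, or whether a longer chain ending in a hydroxyl group or an amine would behave like propyl. They also leave open whether propyl would have a similar effect on the core of compound 1.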